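Bromophenyl enones with benzylsulfanyl chains: growth inhibition notes

The compounds below may be only part of what the source reports. "The series", "measured", "known", "first", "only" and "open" are said of these compounds alone.

Compound 1 `O=C(/C(=C\c1ccc(Br)cc1)SCc1ccc(Cl)cc1)c1ccc(Br)cc1`, compound 2 `COc1ccc(/C=C(/SCc2ccc(Cl)cc2)C(=O)c2ccc(Br)cc2)cc1O` and compound 3 `COc1ccc(/C=C(/SCc2ccc(F)cc2)C(=O)c2ccc(Br)cc2)cc1O` share an enone core carrying a benzylsulfanyl chain. In a functional assay on DU-145 cells (Homo sapiens) for inhibition, read by trypan blue exclusion, with a stated time of 96 h (on this read-out lower numbers stand for stronger inhibition of growth and higher numbers for weaker inhibition of growth), compound 1 gives 1000 nM. Compound 2 gives 1000 nM in this assay, and compound 3 gives 1000 nM. The change 4-bromophenyl in place of 3-hydroxy-4-methoxyphenyl on a double-bonded chain carbon bound to a double-bonded chain carbon produced no change at the digits printed from compound 2 to compound 1 (within the scatter). The change fluoro in place of chloro on an aromatic carbon produced no change at the digits printed from compound 2 to compound 3 (within the scatter), so the three values sit level within the scatter.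

Compound 4 `O=C(/C(=C\c1ccc(Br)cc1)SCc1ccc(F)cc1)c1ccc(Br)cc1` has not yet been measured in this assay. It arises from compound 3 by 4-bromophenyl in place of 3-hydroxy-4-methoxyphenyl on a double-bonded chain carbon bound to a double-bonded chain carbon. This is the same change as from compound 2 to compound 1, and the two cores differ by fluoro in place of chloro on an aromatic carbon. The expected step from compound 3 to compound 4 in this assay is no change at the digits printed from compound 3 to compound 4 (within the scatter), resting on the earlier no change at the digits printed from compound 2 to compound 1 (within the scatter) and on the fact that compounds 1, 2 and 3 all sit level. Compound 4 is therefore estimated at 1000 nM, with a range from 500 nM to 2000 nM. Whether the bromophenyl and fluorobenzyl combination moves it beyond the scatter remains to be measured.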

Compound 4, concentration for 50% growth inhibition: 25000 nM
Estimate against measurement, compound 4: 25-fold (1.40 log units) below, and the stated range ends below it.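

In this assay, 4-bromophenyl in place of 3-hydroxy-4-methoxyphenyl gives a 25-fold higher number from compound 3 to compound 4 (1.40 log units; beyond the scatter), so this change does not carry over unchanged from the core of compound 2 to the core of compound 3: the same change on two cores in this assay, no change at the digits printed (within the scatter) from compound 2 to compound 1 and a 25-fold higher number (1.40 log units; beyond the scatter) from compound 3 to compound 4, 25-fold (1.40 log units) apart, beyond the scatter of two such steps

Read the other way, fluoro in place of chloro gives a 25-fold higher number from compound 1 to compound 4 (1.40 log units; beyond the scatter), and this change does not carry over unchanged either: the same change on two cores in this assay, no change at the digits printed (within the scatter) from compound 2 to compound 3 and a 25-fold higher number (1.40 log units; beyond the scatter) from compound 1 to compound 4, 25-fold (1.40 log units) apart, beyond the scatter of two such steps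

Among these four compounds the two changes therefore cannot be treated as independent, since only compound 4, which holds both 4-bromophenyl and fluoro, departs from the level of the other three, but this single set shows neither the reason for the departure nor whether it would recur on another core.

The compounds shown leave open whether the weaker growth inhibition is specific to fluoro paired with 4-bromophenyl. A trifluoromethyl or a nitrile in place of fluoro, or an amine or a carboxylic acid in place of the bromine of the 4-bromophenyl, would test how narrow that pairing is.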